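The source may hold more compounds than are shown below. What is called first, only, known or untested is meant among the compounds shown, and "the series" means these compounds.

Working notes on the series. The shared core is carried by compound 1 `O=C(O)c1cc(-c2ccc(-c3ccc(Cl)cc3Cl)cc2)n(Cc2cccnc2)n1`, compound 2 `COc1ccc(-n2nc(C(=O)O)cc2-c2ccc(-c3ccc(Cl)cc3Cl)cc2)cc1` and compound 3 `O=C(O)c1cc(-c2ccc(-c3ccc(Cl)cc3Cl)cc2)nn1Cc1ccccn1`, which differ only in the group on the aromatic nitrogen. In an assay on isolated protein for inhibition of methionine--tRNA ligase, cytoplasmic (Homo sapiens) (on this read-out higher numbers stand for weaker inhibition and lower numbers for stronger inhibition), compound 1 gives only a limit of the assay, > 100000 nM. In this assay compound 2 also gives only a limit, > 100000 nM. In this assay compound 3 gives a number, 22300 nM. Among the compounds with values here, the single pair differing in one place yields a step that the two limits leave unreadable from compound 1 to compound 2, so no step size is available to carry forward. Within the data shown here, the series so far is characterised by the limit of > 100000 nM in this assay, at which 2 of the 3 values shown sit; compound 2 thus stands at a limit, with one further value of the three also a limit and only compound 3 giving a number.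

Compound 4 `O=C(O)c1cc(-c2ccc(-c3ccc(Cl)cc3Cl)cc2)n(CCO)n1` differs from compound 2 by 2-hydroxyethyl in place of 4-methoxyphenyl on an aromatic nitrogen. Among the measured compounds shown here, no measured step bears on this change, and the one step recorded is unreadable, so no size or direction can be taken from the data. The estimate for compound 4 in this assay is therefore 60000 nM, within 15000 nM to 300000 nM. For the measured compounds named here, that estimate implies an at least 1.6-fold lower number from compound 2 to compound 4 (0.22 log units; that floor lies within the scatter) as the expected step, and rests on compound 3, whose value 22300 nM is the only number so far.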

Compound 4, half-maximal inhibitory concentration: > 100000 nM
Compound 4 was reported as a limit; the forecaster's own chance of this, stated with the estimate: 50%; middle value at least 1.6-fold (0.22 log units) from the limit.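

Compound 4 gives only a limit of the assay in this assay, > 100000 nM, so the steps to compound 4 from compound 1 and from compound 2 join two limits and cannot be read. The compounds shown leave open the size of any step from changing the group on the aromatic nitrogen, with compound 3 alone giving a number and the series otherwise resting on: the limit of > 100000 nM in this assay, at which 3 of the 4 values shown sit.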